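Rat liver microsome stability: piperazine chain versus piperidine

The source may hold more compounds than are shown below. What is called first, only, known or untested is meant among the compounds shown, and "the series" means these compounds.

Measured so far in an ADME assay on microsomes from liver (Rattus norvegicus) for metabolic stability, read by LC-MS, with a stated time of 10 min, tested at 0.5 uM; on this read-out lower numbers stand for a less stable compound and higher numbers for a more stable compound:
compound 1, `CN1CCN(CCCN(C[C@H]2Cc3ccccc3CN2)[C@H]2CCCc3cccnc32)CC1`: 10%
compound 2, `c1cnc2c(c1)CN[C@H](CN(CCCN1CCNCC1)[C@H]1CCCc3cccnc31)C2`: 87%
compound 3, `c1ccc2c(c1)CN[C@@H](CN(CCCCN1CCNCC1)[C@H]1CCCc3cccnc31)C2`: 15%

Compound 3 holds the second highest of the three numbers. For the measured compounds named here, its nearest neighbour is compound 1, and the one step that runs between them, a number 5 percentage points higher from compound 1 to compound 3 (within the scatter), lies within the scatter, so the two cannot be told apart on this read-out. Going by the values given here, compound 2 sits furthest away; it carries a different shared core as well as a different chain, and no single-point step links it to compound 3, so its two values only show that compound 2 is far above compound 3, beyond the scatter.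

The next compound, compound 4, `c1ccc2c(c1)CN[C@@H](CN(CC[C@@H]1CCCNC1)[C@H]1CCCc3cccnc31)C2`, differs from compound 3 as follows: piperidin-3-yl in place of 2-(piperazin-1-yl)ethyl on a saturated chain carbon, two bonds along the chain from an amine nitrogen. Among the compounds with values here, no measured step covers this exchange. Within the data shown here, the only step in the same region of the molecule is the one from compound 1 to compound 3, which stayed within the scatter. On that basis no step beyond the scatter is expected in this assay, with a slight lean upward allowed by the wide spread in the small set.

Compound 4 is therefore estimated at 20% (range 5% to 45%), an expected step of a number 5 percentage points higher from compound 3 to compound 4 (within the scatter).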

Compound 4, percent of the compound remaining: 28%
Beside the measured number, compound 4's estimate is 8 percentage points below it, within the range that was stated.
By their numbers in this assay, from the lowest: compounds 1 and 3 (each within the scatter of the next); then compound 4; then compound 2.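

In this assay, for the compounds shown here, the exchange of 2-(piperazin-1-yl)ethyl for piperidin-3-yl on a saturated chain carbon, two bonds along the chain from an amine nitrogen, gives the first step at this position on the shared core that clears the scatter: a number 13 percentage points higher from compound 3 to compound 4 (beyond the scatter). The same group set against (4-methylpiperazin-1-yl)methyl gives a number 18 percentage points higher from compound 1 to compound 4 (beyond the scatter), whereas the exchange between those two piperazine chains gave only a number 5 percentage points higher from compound 1 to compound 3 (within the scatter), so among compounds 1, 3 and 4 the piperidin-3-yl compound stands apart from both piperazine compounds, though only by a modest margin. No measurement at hand bears on what lies behind this difference.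

The exchange alters the ring and the chain together, as the same difference cut one bond further out, 3-(piperazin-1-yl)propyl to (piperidin-3-yl)methyl, also shows, so the compounds shown do not tell which of the two carries the step. A 2-(piperidin-3-yl)ethyl group or a (piperazin-2-yl)methyl group at this place would separate ring from chain, and the opposite stereoisomer of piperidin-3-yl would address the defined stereocentre that the new group brings.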